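The source may hold more compounds than are shown below. What is called first, only, known or untested is meant among the compounds shown, and "the series" means these compounds.

Compound 1 `O=C(N/N=C/c1cccc(Br)c1)Nc1ccc(Oc2ccnc3[nH]ccc23)c(F)c1`: 660 nM
Compound 2 `O=C(N/N=C/c1cccc([N+](=O)[O-])c1)Nc1ccc(Oc2ccnc3[nH]ccc23)c(F)c1`: 5180 nM

In a functional assay on HepG2 cells (Homo sapiens) for antiproliferative activity, read by MTT assay, with a stated time of 72 h (on this read-out lower numbers stand for stronger inhibition and higher numbers for weaker inhibition), compound 2 gives 5180 nM and holds the higher of the two numbers. Compound 3 `O=C(N/N=C/c1ccc(O)cc1)Nc1ccc(Oc2ccnc3[nH]ccc23)c(F)c1` differs from it by 4-hydroxyphenyl in place of 3-nitrophenyl on a carbon with a double bond to nitrogen. For the measured compounds named here, only one measured step bears on this change: a 7.8-fold higher number from compound 1 to compound 2 (0.89 log units; beyond the scatter), with nitro in place of bromo on an aromatic carbon. Going by the values given here, that step shows the number shifting with the substituent, but no hydroxy compound has been measured. Losing the nitro group is expected to give a 2.6-fold lower number from compound 2 to compound 3 (0.41 log units; beyond the scatter), a modest move toward stronger inhibition. For compound 3 the estimate is 2000 nM, with an expected range from 500 nM to 8000 nM.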

Compound 3, half-maximal inhibitory concentration: 1950 nM
Estimate against measurement, compound 3: 1.0-fold (0.01 log units) above; the range from low to high includes it.
By their numbers in this assay, from the lowest: compound 1; then compound 3; then compound 2.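

At the aryl group on a carbon with a double bond to nitrogen, 4-hydroxyphenyl lands between the two earlier groups in this assay: a 2.7-fold lower number from compound 2 to compound 3 (0.42 log units; beyond the scatter), and a 3.0-fold higher number from compound 1 to compound 3 (0.47 log units; beyond the scatter). The three aryl groups therefore give three separate levels, with 4-hydroxyphenyl beyond the scatter from both 3-nitrophenyl and 3-bromophenyl. Nothing available explains this order.

The substituent and its place on the ring change together in these steps, so the compounds shown leave open which of the two sets the number. From the compounds shown here alone, how an amine or a carboxylic acid on this ring would read also remains open.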